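This account rests on a few compounds, and the source may have more. Where it says the series, first, only, none or still open, it means among the compounds named here.

Of the compounds shown here, two have a measured number so far. Compound 1 `N=C(NCCCc1c[nH]cn1)NCCSC(c1ccccc1)c1ccccn1` gives 100 nM in a functional assay on ileum for antagonist activity at histamine H1 receptor (Cavia porcellus); a higher number here means weaker binding, a lower number tighter binding. Compound 2 `N=C(NCCCc1c[nH]cn1)NCCCC(c1ccccc1)c1ccccn1` gives 251 nM in this assay, the higher of the two numbers, and its gap to compound 1 lies beyond the usual scatter of repeated measurements. Compound 3 `N=C(NCCCc1c[nH]cn1)NCCCC(c1ccc(F)cc1)c1ccccn1` has not yet been measured. It differs from compound 2 by a single change, (fluoro in place of hydrogen on an aromatic carbon). Among the measured compounds shown here, no pair of measured compounds shows what this kind of change does here, so the expectation rests only on where compound 2 stands. The step of a 1.1-fold lower number from compound 2 to compound 3 (0.06 log units; within the scatter) is expected to be small, with no clear direction and most likely within the scatter. Compound 3 is therefore expected to give about 220 nM in this assay, with a likely range from 90 nM to 550 nM.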

Compound 3, dissociation constant: 46.8 nM
Compound 3: middle estimate off by 4.7-fold (0.67 log units), on the high side; the measured number lies below the stated range.
By their numbers in this assay, from the lowest: compound 3; then compound 1; then compound 2.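

In this assay, going from phenyl to 4-fluorophenyl gives a 5.4-fold lower number from compound 2 to compound 3 (0.73 log units; beyond the scatter), so this place, on an aromatic carbon para to a large group, is not indifferent to substitution. A single fluoro in place of hydrogen, with one heavy atom and no ring, hydrogen-bond donor, hydrogen-bond acceptor or net charge, is enough to tighten binding in this series. This is the only step shown for a change on this ring, so it stands as a single observation rather than a trend. Nothing measured here bears on why the number moves. The compounds shown leave open whether chloro, methoxy or trifluoromethyl at the same place would act as fluoro does. On these data alone, whether fluoro at this place on the core of compound 1 would give a step of similar size also stays open.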